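Swapping a Nitrile for a Chlorobenzyl: Expected Cytotoxicity

The source may report more compounds than this note shows. Statements on the series, on what has been measured and on what is new or still open speak of the compounds shown alone.

Compound 1, `CCC1(Cc2ccccc2)OS(=O)(=O)C=C1OCC#N`, is one of two compounds built on a shared core that have been tested for toxicity toward cultured cells. In an ADME assay on HEL cells (Homo sapiens) for cytotoxicity, with a stated time of 3 days (on this read-out higher numbers stand for lower toxicity in this test and lower numbers for higher toxicity in this test), compound 1 reaches only the limit of the test, > 200000 nM, so its result is a boundary of the assay rather than a number. The other measured compound, compound 2, `CC1(C(c2ccccc2)c2ccccc2)OS(=O)(=O)C=C1OCc1ccccc1`, carries different groups on the same core and gives 200000 nM in this assay. Both results sit at the top of what the test can report, as the record the limit of > 200000 nM in this assay, at which 1 of the 2 values shown sits, shows, and nothing here separates the two. No pair of these compounds differs in only one place, so no measured step between them exists.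

Compound 3, `CCC1(Cc2ccccc2)OS(=O)(=O)C=C1OCc1ccccc1Cl`, has not yet been measured. It differs from compound 1 in one place: 2-chlorophenyl in place of cyano on a saturated chain carbon bound to an oxygen on an unsaturated carbon. No step beyond the usual scatter is expected, a number no higher from compound 1 to compound 3 (the limit leaves the size open). Compound 3 is therefore estimated at 200000 nM, within a range from 60000 nM to 200000 nM, with a real chance that this assay again reports only its limit.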

Compound 3, half-maximal cytotoxic concentration: 38000 nM
Beside the measured number, compound 3's estimate is 5.3-fold (0.72 log units) above it, outside the stated range (below it).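

Going by these compounds alone, this step is the first direct evidence on this position, since the earlier compounds differed in more than one place and offered no step to read. In this assay, 2-chlorophenyl in place of cyano gives an at least 5.2-fold lower number from compound 1 to compound 3 (0.72 log units; beyond the scatter), which is beyond the usual scatter and moves toward higher toxicity in this test, so the group carried on this saturated chain carbon can change the result. Compound 1 has only a limit, so the step is a minimum and its full size remains unknown, because the starting point is not an exact number: the limit of > 200000 nM in this assay, at which 1 of the 3 values shown sits.

The compounds shown leave open whether the change goes with the chlorine or with the aromatic ring that carries it, since no pair here differs by the chlorine alone. They also do not tell how a plain phenyl, an amine or a carboxylic acid in this place would read in this assay, or whether the same swap would give a similar step with the different groups that compound 2 carries on the shared core.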